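One Aryl Swap on a Saturated Ring Carbon

The source may hold more compounds than are shown below. What is called first, only, known or untested is meant among the compounds shown, and "the series" means these compounds.

Measured compounds:
compound 1, `CC(C)(C)C1=NN(c2ccc(F)c(F)c2F)C(c2ccc(O)cc2)C1`: 3100 nM
compound 2, `CC(C)(C)C1=NN(c2ccc(Cl)cc2)C(c2ccc(F)cc2)C1`: "not determined" (no result reported)

Among the measured compounds shown here, compound 1 `CC(C)(C)C1=NN(c2ccc(F)c(F)c2F)C(c2ccc(O)cc2)C1` is the only compound with a number: in an assay on U-937 cells for inhibition of protein kinase C zeta type (Homo sapiens), read by reporter gene assay (a higher number here means a weaker inhibitor, a lower number a stronger inhibitor), compound 1 gives 3100 nM. Compound 2 `CC(C)(C)C1=NN(c2ccc(Cl)cc2)C(c2ccc(F)cc2)C1` has no result in this assay, where the entry for compound 2 reads "not determined" (no result reported), so it stands nowhere on the numbers shown; there is no value to place it above or below compound 1.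

Compound 3 `CC(C)(C)C1=NN(c2ccc(Cl)cc2)C(c2ccc(O)c(Cl)c2)C1` differs from compound 2 in one place: 3-chloro-4-hydroxyphenyl in place of 4-fluorophenyl on a saturated ring carbon. For the measured compounds named here, no step between two measured compounds exists here, and compound 2 has no starting number, so neither the direction nor the size of the move from compound 2 to compound 3 in this assay can be read from the data; it may be none beyond the scatter or a real shift. Going by the values given here, the only anchor is compound 1.

Compound 3 is therefore expected to land in the same region as compound 1 in this assay, estimated at about 3000 nM, with a likely range from 700 nM to 13000 nM, a wide band because 3100 nM for compound 1 is the sole reference point.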

Compound 3, half-maximal inhibitory concentration: 2900 nM
For compound 3 the middle estimate is 1.0-fold (0.01 log units) above the measured one; the measured number falls inside the stated range.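

In this assay, among the compounds shown here, compound 3 gives 2900 nM, but compound 2 has no number to set beside it, so no step between compound 2 and compound 3 can be read. The compounds shown leave open what replacing 4-fluorophenyl with 3-chloro-4-hydroxyphenyl does to inhibition on its own. Nothing shown offers an explanation for the value of compound 3.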